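This account rests on a few compounds, and the source may have more. Where it says the series, first, only, none or still open, it means among the compounds named here.

In an ADME assay on HepG2 cells (Homo sapiens) for cytotoxicity, read by luminescence, with a stated time of 72 h (a lower number here means that less compound is needed, a higher number that more compound is needed for the effect), compound 1 (`CCOC(=O)c1c(-c2cccc(Oc3ccccc3)c2)[nH]c2cc(OC)ccc2c1=O`) gives > 21500 nM, which is a limit and not a number. Compound 2 (`CCOC(=O)c1c(-c2cccc(S(C)(=O)=O)c2)[nH]c2cc(OC)ccc2c1=O`), with methylsulfonyl in place of phenoxy on an aromatic carbon, gives > 21500 nM, again a limit. Compound 3 (`CCOC(=O)c1c(-c2cccc(Oc3ccccc3)c2)[nH]c2cc(OC)c(OC)cc2c1=O`), with methoxy in place of hydrogen on an aromatic carbon, gives > 21500 nM, also a limit. The whole record so far is therefore (the limit of > 21500 nM in this assay, at which 3 of the 3 values shown sit).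

The first change amounts to a step that the two limits leave unreadable from compound 1 to compound 2, and the second to a step that the two limits leave unreadable from compound 1 to compound 3. Neither has a readable size, and neither alters the ethyl chain of the ester.

Compound 4 (`COc1ccc2c(=O)c(C(=O)OCCCN(C)C)c(-c3cccc(Oc4ccccc4)c3)[nH]c2c1`) keeps the core of compound 1 and changes exactly that chain: (dimethylamino)methyl in place of hydrogen on a saturated chain carbon, two bonds along the chain from an oxygen next to a carbonyl group. Cut one bond further out, the same difference reads ethyl to 3-(dimethylamino)propyl. Going by the values given here, none of the measured compounds carries such a chain, so the data offer no step size to carry over. Any forecast is correspondingly loose, and the assay may again return only a limit. The expected change is an at least 1.3-fold lower number from compound 1 to compound 4 (0.12 log units; that floor lies within the scatter), a tentative lean towards less compound being needed. For compound 4 the estimated value is 16000 nM, with an expected range from 5000 nM to 40000 nM.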

Compound 4, half-maximal effective concentration: > 21500 nM
Compound 4: no number, only a limit; the forecaster's own chance of this, stated with the estimate: 50%; middle value at least 1.3-fold (0.12 log units) from the limit.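

In this assay compound 4 gives > 21500 nM, again a limit and not a number, so the step between compound 1 and compound 4 cannot be read. The record now stands as follows: the limit of > 21500 nM in this assay, at which 4 of the 4 values shown sit. The compounds shown leave open how far any of the four lies past that limit, and what change to them would give a readable number.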